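Styrylxanthine MAO-B inhibition: from methoxyphenyl to aminopyridinyl

A few compounds are considered here, and "the series" means these few. Any claim that something is new, unique, unknown or untested is made for them only; others in the source may bear on it.

Measured compounds:
compound 1 `Cn1c(=O)c2c(cc(/C=C/c3cccc(Cl)c3)n2C)n(C)c1=O`: 1480 nM
compound 2 `COc1cccc(/C=C/c2cc3c(c(=O)n(C)c(=O)n3C)n2C)c1`: 370 nM
compound 3 `Cn1c(=O)c2c(cc(/C=C/c3ccc(C(F)(F)F)cc3)n2C)n(C)c1=O`: 432 nM

In an assay on isolated protein for inhibition of Amine oxidase [flavin-containing] B (Homo sapiens), read by luminescence, with a stated time of 1 h (on this read-out lower numbers stand for stronger inhibition and higher numbers for weaker inhibition), compound 2 gives 370 nM, the lowest number of the three. Compound 3 gives 432 nM, within the scatter of compound 2, so no order between them can be claimed. Compound 1 gives 1480 nM, and the step of a 4.0-fold lower number from compound 1 to compound 2 (0.60 log units; beyond the scatter) lies beyond the scatter.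

Compound 4 `Cn1c(=O)c2c(cc(/C=C/c3cccc(N)n3)n2C)n(C)c1=O` is not yet measured. It differs from compound 2 by 6-aminopyridin-2-yl in place of 3-methoxyphenyl on a double-bonded chain carbon bound to a double-bonded chain carbon. Within the data shown here, no measured step exchanges the carbocyclic ring for a ring with a hetero atom or introduces a hydrogen-bond donor, so the only guidance is the spread among compounds 1, 2 and 3, where the aryl substituent changes move the numbers by up to the size of a 4.0-fold lower number from compound 1 to compound 2 (0.60 log units; beyond the scatter). An increase in number, that is weaker inhibition, is expected for compound 4 in this assay, of about a 4.1-fold higher number from compound 2 to compound 4 (0.61 log units; beyond the scatter). Compound 4 is therefore estimated at 1500 nM, with a range from 300 nM to 8000 nM.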

Compound 4, half-maximal inhibitory concentration: > 10000 nM
Compound 4 was reported as a limit; the forecaster's own chance of this, stated with the estimate: 10%; middle value at least 6.6-fold (0.82 log units) from the limit.
By their numbers in this assay, from the lowest: compounds 2 and 3 (each within the scatter of the next); then compound 1. At a limit, above all of these: compound 4.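

Compound 4 is reported only as a limit in this assay: the limit of > 10000 nM in this assay, at which 1 of the 4 values shown sits. Placing 6-aminopyridin-2-yl in place of 3-methoxyphenyl on a double-bonded chain carbon bound to a double-bonded chain carbon gives an at least 27-fold higher number from compound 2 to compound 4 (1.43 log units; beyond the scatter), whereas compounds 1, 2 and 3, which all carry a ring of carbon only, each gave a measured number. Against the 3-chlorophenyl group, the same exchange gives an at least 6.7-fold higher number from compound 1 to compound 4 (0.82 log units; beyond the scatter), so this position does not accept every aromatic ring.

The exchange brings in the ring nitrogen and the amine together, and the compounds shown cannot separate the two. A plain pyridinyl ring without the amine, or an aminophenyl ring without the ring nitrogen, would show which of them goes with the loss.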